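Compound 4: methoxy in place of fluoro

The source may report more compounds than this note shows. Statements on the series, on what has been measured and on what is new or still open speak of the compounds shown alone.

In an ADME assay on MT4 cells (Homo sapiens) for cytotoxicity, read by MTT assay (a lower number here means that less compound is tolerated, a higher number that more compound is tolerated), compound 3 `CCC(C)c1c(Cc2c(F)cccc2Cl)nc(SCC(=O)c2ccc(F)cc2)[nH]c1=O` gives > 54000 nM, which is a limit and not a number. The change to compound 4 `CCC(C)c1c(Cc2c(F)cccc2Cl)nc(SCC(=O)c2ccc(OC)cc2)[nH]c1=O` is methoxy in place of fluoro on an aromatic carbon, described as methoxy in place of fluoro on an aromatic carbon, para to a large group. Among the compounds with values here, no measured step covers this change directly. Within the data shown here, the one measured step, a step that the two limits leave unreadable from compound 1 to compound 2, is isopropyl in place of methyl, so it concerns a different place and offers no readable size. The closest guide is the 4-methoxyphenyl group itself, which two measured compounds already carry. Compound 1 `COc1ccc(C(=O)CSc2nc(Cc3c(F)cccc3Cl)c(C)c(=O)[nH]2)cc1` carries it and gives > 12000 nM, also a limit. Compound 2 `COc1ccc(C(=O)CSc2nc(Cc3c(F)cccc3Cl)c(C(C)C)c(=O)[nH]2)cc1` carries it too and gives > 11000 nM, again a limit. Neither limit fixes a number, so the expectation remains loose. The expected step is an at least 3.6-fold lower number from compound 3 to compound 4 (0.55 log units; beyond the scatter), towards a lower number in this assay, and its size is uncertain. In this assay the estimate for compound 4 is 15000 nM, expected to lie in the range from 8000 nM to 60000 nM.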

Compound 4, half-maximal cytotoxic concentration: 40000 nM
The estimate for compound 4 lay 2.7-fold (0.43 log units) below the measured number; the range from low to high includes it.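

Compound 4 is the first compound shown to give a number rather than a limit in this assay, at 40000 nM. Putting 4-methoxyphenyl in place of 4-fluorophenyl gives an at least 1.3-fold lower number from compound 3 to compound 4 (0.13 log units; that floor lies within the scatter), and the real step may be larger because compound 3 is held only by a limit: the limit of > 54000 nM in this assay, at which 1 of the 4 values shown sits. The steps from compound 1 and from compound 2 to compound 4 cannot be read, so the sec-butyl compound 4 cannot yet be set against its methyl and isopropyl counterparts.

As far as these compounds go, what stays open is how large the step from 4-fluorophenyl to 4-methoxyphenyl really is, and whether it would look the same with methyl or isopropyl in place of sec-butyl. Also open, from the compounds shown here alone, is how an amine or a carboxylic acid in place of the methoxy would read in this assay.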